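A New Cap on the Octadecyl Chain Compound

The source may report more compounds than this note shows. Statements on the series, on what has been measured and on what is new or still open speak of the compounds shown alone.

In a functional assay on SiHa cells (Homo sapiens) for cytotoxicity, read by MTT assay, with a stated time of 48 h (on this read-out higher numbers stand for weaker inhibition and lower numbers for stronger inhibition), compound 1 `CCCCCCCCCCCCNC(=O)[C@@H](NS(=O)(=O)c1ccc(C)cc1)[C@@H](C)O` gives 31600 nM and compound 2 `CCCCCCCCCCCCCCNC(=O)[C@@H](NC(=O)c1cc2ccccc2o1)[C@@H](C)O` gives 14200 nM. For compound 3 `CCCCCCCCCCCCCCCCCCNC(=O)[C@@H](NC(=O)c1cc2ccccc2o1)[C@@H](C)O` this assay reports only a limit, > 200000 nM. Compound 3 thus sits at the far end of the numbers shown, at the limit of > 200000 nM in this assay, at which 1 of the 3 values shown sits. Lengthening the chain gave an at least 14-fold higher number from compound 2 to compound 3 (1.14 log units; beyond the scatter). Compound 4 `CCCCCCCCCCCCCCCCCCNC(=O)[C@@H](NS(=O)(=O)c1ccc(C)cc1)[C@@H](C)O` keeps that long chain and carries (4-methylphenyl)sulfonyl in place of (1-benzofuran-2-yl)carbonyl on an amine nitrogen. Among the measured compounds shown here, no measured step isolates this cap swap on its own; compound 1 and compound 2 differ in both the cap and the chain, so their two values cannot separate the two changes. Compound 4 is therefore expected to remain near the limit, with the step of a number no higher from compound 3 to compound 4 (the limit leaves the size open) estimated as small. For compound 4 in this assay the estimate is 200000 nM, with a range from 60000 nM to 600000 nM.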

Compound 4, half-maximal inhibitory concentration: 29800 nM
Compound 4: the middle estimate sits 6.7-fold (0.83 log units) above what was measured, outside the stated range (below it).
By their numbers in this assay, from the lowest: compound 2; then compounds 4 and 1 (each within the scatter of the next). At a limit, above all of these: compound 3.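

On the amine nitrogen of the octadecyl compounds the cap clearly counts: in this assay, (4-methylphenyl)sulfonyl in place of (1-benzofuran-2-yl)carbonyl gives an at least 6.7-fold lower number from compound 3 to compound 4 (0.82 log units; beyond the scatter). From the compounds shown here alone, compound 3 carries only a limit, so the full size of that step stays unknown: the limit of > 200000 nM in this assay, at which 1 of the 4 values shown sits. With the (4-methylphenyl)sulfonyl cap kept, the longer chain gives a 1.1-fold lower number from compound 1 to compound 4 (0.03 log units; within the scatter), unlike the sharp rise seen with the (1-benzofuran-2-yl)carbonyl cap, an at least 14-fold higher number from compound 2 to compound 3 (1.14 log units; beyond the scatter).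

Going by these compounds, what an acetyl group on this nitrogen would do stays open, as does the effect of a hexadecyl chain under either cap.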